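This account rests on a few compounds, and the source may have more. Where it says the series, first, only, none or still open, it means among the compounds named here.

Compound 1 `CC(C)Oc1nc(N)nc2ncc(-c3ccc(F)c(F)c3)nc12`: 10000 nM
Compound 2 `CC(C)Oc1nc(N)nc2ncc(-c3ccc(C#N)cc3)nc12`: > 10000 nM
Compound 3 `COc1ccc(-c2cnc3nc(N)nc(N4CCN(Cc5c(Cl)cccc5Cl)CC4)c3n2)cc1OC`: 7600 nM

All three were tested in a functional assay on cells (T-cell, Homo sapiens) for inhibition; a higher number here means a weaker inhibitor, a lower number a stronger inhibitor. Compound 1 and compound 3 give numbers that lie within the scatter of each other, so no order between them can be read. For compound 2 the value is a limit of the assay, not a number, as marked by the limit of > 10000 nM in this assay, at which 1 of the 3 values shown sits. Compound 4 `COc1ccc(-c2cnc3nc(N)nc(N4CCN(Cc5ccc(C(C)(C)C)cc5)CC4)c3n2)cc1OC` has not yet been measured. It differs from compound 3 in one place: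

4-(tert-butyl)phenyl in place of 2,6-dichlorophenyl on a saturated chain carbon bound to an amine nitrogen in a ring

For the measured compounds named here, no measured pair shows the effect of this change, so the expected step from compound 3 to compound 4 in this assay is small, in no clear direction, and likely within the scatter: a 1.1-fold higher number from compound 3 to compound 4 (0.02 log units; within the scatter). On that basis compound 4 is estimated at 8000 nM, with a range from 2000 nM to 30000 nM.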

Compound 4, half-maximal inhibitory concentration: 4300 nM
Compound 4: the middle estimate sits 1.9-fold (0.27 log units) above what was measured; measured number inside the range.
By their numbers in this assay, from the lowest: compounds 4, 3 and 1 (each within the scatter of the next, the first and the last beyond it).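

Replacing 2,6-dichlorobenzyl with 4-(tert-butyl)benzyl gives a 1.8-fold lower number from compound 3 to compound 4 (0.25 log units; within the scatter) in this assay and so leaves the result within the scatter. At this place, on a saturated chain carbon bound to an amine nitrogen in a ring, one benzyl group carrying chlorine and another made of carbon only give numbers that cannot be told apart. Nothing measured here offers a reason for this step. As far as these compounds go, what a benzyl group carrying an amine or a carboxylic acid would give at this place remains open, as does the result for an unsubstituted benzyl group.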